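Benzoyl for Acetyl on an Inactive Anilide Pair

The source may hold more compounds than are shown below. What is called first, only, known or untested is meant among the compounds shown, and "the series" means these compounds.

Compound 1, `CC(=O)Nc1cc(NC(=O)c2ccc(Cl)c(C(F)(F)F)c2)ccc1C`, in a functional assay on A375P cells (Homo sapiens) for antiproliferative activity (on this read-out lower numbers stand for stronger inhibition and higher numbers for weaker inhibition), gives > 30000 nM, a limit of the assay.
Compound 2, `CC(=O)Nc1cc(NC(=O)c2cc(C)on2)ccc1C`, in this assay gives > 30000 nM, a limit of the assay.
Compound 3, `Cc1ccc(NC(=O)c2ccc(Cl)c(C(F)(F)F)c2)cc1NC(=O)c1ccccc1`, in this assay gives > 30000 nM, a limit of the assay.

Compound 3 differs from compound 1 by phenyl in place of methyl on a carbonyl carbon. The step that the two limits leave unreadable from compound 1 to compound 3 cannot be read because of the limit of > 30000 nM in this assay, at which 3 of the 3 values shown sit. How the core of compound 2 differs from that of compound 1 is not broken down here. Compound 4, `Cc1cc(C(=O)Nc2ccc(C)c(NC(=O)c3ccccc3)c2)no1`, differs from compound 2 by phenyl in place of methyl on a carbonyl carbon, the same change as from compound 1 to compound 3. Since all three measured values sit at a limit, the expected step that the limit leaves unreadable from compound 2 to compound 4 rests only on the unreadable a step that the two limits leave unreadable from compound 1 to compound 3, and compound 4 is most likely to return a limit as well. For compound 4 in this assay the estimate is 40000 nM, between 10000 nM and 150000 nM.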

Compound 4, half-maximal inhibitory concentration: > 30000 nM
Compound 4 was reported as a limit (the forecaster's own chance of this, stated with the estimate: 80%); the middle value does not contradict the limit.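

No new step can be read from compound 2 to compound 4, as both stand at the same limit of the assay: the limit of > 30000 nM in this assay, at which 4 of the 4 values shown sit.

The compounds shown leave open whether acetyl to benzoyl changes anything in this assay, and how strongly any of the four compounds acts there.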